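This account rests on a few compounds, and the source may have more. Where it says the series, first, only, none or still open, it means among the compounds named here.

In a functional assay on P388 cells (Mus musculus) for cytotoxicity (on this read-out lower numbers stand for stronger inhibition and higher numbers for weaker inhibition), compound 3 `C=C/C=C\[C@H](C)[C@H](OC(N)=O)[C@@H](C)[C@H](O)[C@@H](C)C/C(C)=C\[C@H](C)[C@@H](O)[C@@H](C)/C=C\[C@@H](O)C[C@@H]1OC(=O)C(C)=C[C@H]1C` gives 33.6 nM and sits within the scatter of compound 1 `CCCC[C@H](C)[C@H](OC(N)=O)[C@@H](C)[C@H](O)[C@@H](C)C/C(C)=C\[C@H](C)[C@@H](O)[C@@H](C)CC[C@@H](O)C[C@@H]1OC(=O)[C@H](C)[C@@H](O)[C@H]1C` at 33.8 nM on these numbers. Compound 2 `C=C/C=C\[C@H](C)[C@H](OC(N)=O)[C@@H](C)[C@H](OC(C)=O)[C@@H](C)C/C(C)=C\[C@H](C)[C@@H](O)[C@@H](C)/C=C\[C@@H](O)C[C@@H]1OC(=O)C(C)=C[C@H]1C` stands at > 8100 nM as a limit of the assay. Compound 4 `C=C/C=C\[C@H](C)[C@H](OC(N)=O)[C@@H](C)[C@H](O)[C@@H](C)C/C(C)=C\[C@H](C)[C@@H](OC(C)=O)[C@@H](C)/C=C\[C@@H](O)C[C@@H]1OC(=O)C(C)=C[C@H]1C` differs from compound 3 by acetyl in place of hydrogen on an oxygen on a saturated carbon as acetyl in place of hydrogen on an oxygen on a saturated carbon. Going by the values given here, the one measured step bearing on this is the reverse exchange on a different oxygen, an at least 240-fold lower number from compound 2 to compound 3 (2.38 log units; beyond the scatter) and large. Read backwards, that step points to a higher number in this assay beyond the scatter, but with the oxygen differing, a smaller rise is expected. The expected step is a 24-fold higher number from compound 3 to compound 4 (1.38 log units; beyond the scatter) in that direction. Compound 4 is estimated at 800 nM with an expected range from 120 nM to 6000 nM in this assay.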

Compound 4, half-maximal inhibitory concentration: 519 nM
Beside the measured number, compound 4's estimate is 1.5-fold (0.19 log units) above it; the range from low to high includes it.
By their numbers in this assay, from the lowest: compounds 3 and 1 (each within the scatter of the next); then compound 4. At a limit, above all of these: compound 2.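

In this assay, acetyl on this oxygen carries a large penalty: a 15-fold higher number from compound 3 to compound 4 (1.19 log units; beyond the scatter). A second hydroxy of the chain therefore also responds to acetylation, and here the outcome is a measured number rather than a limit. Compound 2, with acetyl on a different oxygen, rests on a limit of the assay, so the two steps cannot be sized against each other: the limit of > 8100 nM in this assay, at which 1 of the 4 values shown sits. As far as these compounds go, whether a methyl ether or a longer acyl chain such as butyryl on this oxygen gives a smaller or larger step stays open, as does the effect of acetyl on the remaining hydroxy groups.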